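The source may report more compounds than this note shows. Statements on the series, on what has been measured and on what is new or still open speak of the compounds shown alone.

Measured so far:
compound 1 `Cc1noc(C)c1-c1cccc(COc2ccc3c(c2)OCC3CC(=O)O)c1` — 27.5 nM
compound 2 `Cc1noc(C)c1-c1cc(COc2ccc3c(c2)OCC3CC(=O)O)ccc1Cl` — 18.6 nM
compound 3 `Cc1noc(C)c1-c1cc(COc2ccc3c(c2)OC[C@H]3CC(=O)O)ccc1Cl` — not yet measured

In a functional assay on CHO cells for agonist activity at Free fatty acid receptor 1 (Homo sapiens), read by FLIPR and calcium flux (on this read-out lower numbers stand for an effect already at smaller amounts and higher numbers for an effect only at larger amounts of compound), compound 2 gives the lowest of the two numbers, but its nearest neighbour is compound 1 and the step of a 1.5-fold lower number from compound 1 to compound 2 (0.17 log units; within the scatter) lies within the scatter, so the two cannot be ordered against each other. The change from compound 2 to compound 3 is this: the two compounds have the same atoms and bonds; at least one stereo element is drawn with a configuration in one of them and without one in the other: 1 of 1 stereo elements differ; a stereocentre at a saturated ring carbon is drawn without a configuration in compound 2 and S in compound 3. Among the compounds with values here, the only measured step, that from compound 1 to compound 2, concerns chloro in place of hydrogen on an aromatic carbon and says nothing about a stereocentre; no measured pair bears on the present change. Nothing in the data settles the direction, and the number for compound 3 could come out on either side of that of compound 2. Compound 3 is therefore expected near 12 nM, within 4 nM to 60 nM, an expected step of a 1.6-fold lower number from compound 2 to compound 3 (0.19 log units; within the scatter), not beyond the scatter.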

Compound 3, half-maximal effective concentration in the Free fatty acid receptor 1 assay: 7.9 nM
Estimate against measurement, compound 3: 1.5-fold (0.18 log units) above; measured number inside the range.
By their numbers in the Free fatty acid receptor 1 assay, from the lowest: compound 3; then compounds 2 and 1 (each within the scatter of the next).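

Within the data shown here, in the Free fatty acid receptor 1 assay compound 3 gives 7.9 nM, and the S drawing at the saturated ring carbon gives the first step that lies beyond the scatter, though a modest one (a 2.4-fold lower number from compound 2 to compound 3 (0.37 log units; beyond the scatter)). In a physicochemical assay for lipophilicity, read by HPLC, with a stated time of 24 h, at pH 7.4, tested at 100 uM (a higher number here means a more lipophilic compound, a lower number a more polar compound), compound 2 gives 1.96 and compound 3 gives 1.93, and the same change gives no separation of the two compounds (a number 0.03 log units lower from compound 2 to compound 3 (within the scatter)). Since the atoms and bonds are the same in both compounds, the drawn stereo element is the only structural difference to set against the step in the Free fatty acid receptor 1 assay: the fact that one of compounds 2 and 3 is drawn with a defined configuration and the other without, at the place where they differ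

From the compounds shown here alone, how the R configuration at this ring carbon would read remains open, and with it the size of any gap between the two configurations. Also open, going by these compounds, is whether the S drawing holds its number with fluoro or methoxy in place of the chloro.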